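A Fluorophenyl Analogue Replaces the Naphthyl Group

The source may report more compounds than this note shows. Statements on the series, on what has been measured and on what is new or still open speak of the compounds shown alone.

The measured compounds in a functional assay on WM 266-4 cells (Homo sapiens) for antiproliferative activity, read by MTT assay, with a stated time of 24 h (on this read-out lower numbers stand for stronger inhibition of growth and higher numbers for weaker inhibition of growth), are these. Compound 1, `Clc1ccc(C2CC(c3ccc4c(c3)OCCO4)=NN2c2ccccc2)cc1`, gives 38600 nM. Compound 2, `c1ccc(C2CC(c3ccc4c(c3)OCCO4)=NN2c2ccccc2)cc1`, gives 22400 nM. Compound 3, `c1ccc(N2N=C(c3ccc4c(c3)OCCO4)CC2c2cccc3ccccc23)cc1`, reaches only a limit of the assay, > 100000 nM.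

Compound 3 therefore stands at the upper edge of the numbers shown, at the limit of > 100000 nM in this assay, at which 1 of the 3 values shown sits. Compounds 1 and 2 sit clearly below it: an at least 2.5-fold higher number from compound 1 to compound 3 (0.41 log units; beyond the scatter) and an at least 4.4-fold higher number from compound 2 to compound 3 (0.64 log units; beyond the scatter), both beyond the scatter. Compounds 1 and 2 themselves lie close together, since a 1.7-fold lower number from compound 1 to compound 2 (0.24 log units; within the scatter).

Compound 4, `Fc1ccc(C2CC(c3ccc4c(c3)OCCO4)=NN2c2ccccc2)cc1`, differs from compound 3 in one place: 4-fluorophenyl in place of naphthalen-1-yl on a saturated ring carbon. This change undoes the move that took compounds 1 and 2 up to compound 3, and the chloro-to-hydrogen step between compounds 1 and 2 suggests that a halogen on that phenyl ring matters little. Compound 4 is thus expected to step down from the limit of compound 3, by an at least 3.3-fold lower number from compound 3 to compound 4 (0.52 log units; beyond the scatter), into the region of compounds 1 and 2. The estimate for compound 4 in this assay is 30000 nM, expected to fall between 12000 nM and 80000 nM.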

Compound 4, concentration for 50% growth inhibition: 6050 nM
Compound 4: the middle estimate sits 5.0-fold (0.70 log units) above what was measured, and the stated range ends above it.
By their numbers in this assay, from the lowest: compound 4; then compounds 2 and 1 (each within the scatter of the next). At a limit, above all of these: compound 3.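

In this assay, hydrogen and chloro on the phenyl ring at this saturated ring carbon had not separated, but fluoro does: a 3.7-fold lower number from compound 2 to compound 4 (0.57 log units; beyond the scatter), and a 6.4-fold lower number from compound 1 to compound 4 (0.80 log units; beyond the scatter). This position therefore responds to which halogen the ring carries, and among the compounds shown, only the change to fluoro moves the number beyond the scatter without adding the naphthalen-1-yl group. Against that group, 4-fluorophenyl gives an at least 16-fold lower number from compound 3 to compound 4 (1.21 log units; beyond the scatter), but the value of compound 3 is a limit of the assay, so the size of this step is only a lower bound: the limit of > 100000 nM in this assay, at which 1 of the 4 values shown sits.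

The compounds shown leave open whether a 4-methoxyphenyl or 4-aminophenyl group in this place would follow 4-fluorophenyl or stay with 4-chlorophenyl. They also leave open whether the gain from fluoro would persist on a core carrying a different group in place of the phenyl on the ring nitrogen.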